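Moving the Chlorine in a Hydrazide Sulfonamide Set

The compounds below may be only part of what the source reports. "The series", "measured", "known", "first", "only" and "open" are said of these compounds alone.

Three hydrazides sharing a sulfonamide core were tested in a functional assay on MDA-MB-231 cells (Homo sapiens) for antiproliferative activity, read by MTT assay, with a stated time of 24 h; a lower number here means a stronger inhibitor, a higher number a weaker inhibitor. Compound 1 `O=C(NNC(=O)c1ccccc1Cl)c1ccc(NS(=O)(=O)c2cnc(O)nc2O)cc1` gives 13900 nM. Compound 2 `O=C(NNC(=O)c1cccc(Cl)c1)c1ccc(NS(=O)(=O)c2cnc(O)nc2O)cc1` gives 4160 nM. Compound 3 `O=C(NNC(=O)c1ccccc1Cl)c1cccc(NS(=O)(=O)c2cnc(O)nc2O)c1` gives 2360 nM. The change 3-chlorophenyl in place of 2-chlorophenyl on a carbonyl carbon produced a step of a 3.3-fold lower number from compound 1 to compound 2 (0.52 log units; beyond the scatter). How the core of compound 3 differs from the core of compound 1 is not broken down here; compound 3 has the lowest number of the three, though its gap to compound 2 lies within the scatter, while its gap to compound 1 lies beyond it.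

Compound 4 `O=C(NNC(=O)c1cccc(NS(=O)(=O)c2cnc(O)nc2O)c1)c1cccc(Cl)c1` has not yet been measured in this assay. It differs from compound 3 by 3-chlorophenyl in place of 2-chlorophenyl on a carbonyl carbon, the same change, at the same kind of place, as the one seen earlier. Going by the values given here, the step expected here is a 2.1-fold lower number from compound 3 to compound 4 (0.33 log units; beyond the scatter), which rests on the single earlier instance, a 3.3-fold lower number from compound 1 to compound 2 (0.52 log units; beyond the scatter), taken with caution as one example only. Compound 4 is therefore expected to give about 1100 nM, with the estimate spanning 400 nM to 3500 nM.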

Compound 4, half-maximal inhibitory concentration: 3180 nM
Compound 4: middle estimate off by 2.9-fold (0.46 log units), on the low side, and the stated range covers the measured number.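

In this assay, putting 3-chlorophenyl in place of 2-chlorophenyl on the carbonyl carbon gives a 1.3-fold higher number from compound 3 to compound 4 (0.13 log units; within the scatter), so this pair cannot be told apart. Set beside the earlier step, the change does not carry over with the same size from the core of compound 1 to the core of compound 3: the same change on two cores in this assay, a 3.3-fold lower number (0.52 log units; beyond the scatter) from compound 1 to compound 2 and a 1.3-fold higher number (0.13 log units; within the scatter) from compound 3 to compound 4, 4.5-fold (0.65 log units) apart, beyond the scatter of two such steps This shows that, in this series, the step seen on one core cannot simply be transferred to the other, but with only two cores it does not explain the difference or show how the change would behave on any further core.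

Going by these compounds, it remains open whether a plain phenyl group, or a bromine or methoxy group in place of the chlorine, would follow either step. On these data alone, it is also open whether an amine in place of the hydroxyl groups on the shared core would alter the size of the step between the two chlorophenyl groups.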